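The source may hold more compounds than are shown below. What is called first, only, known or untested is meant among the compounds shown, and "the series" means these compounds.

Measured so far in a functional assay on A549 cells (Homo sapiens) for cytotoxicity, read by MTT assay, with a stated time of 72 h; a lower number here means a stronger inhibitor, a higher number a weaker inhibitor:
compound 1 `COc1ccc(S(=O)(=O)c2nc3ccccc3nc2Nc2ccc(N)cc2)cc1` — 2990 nM
compound 2 `COc1ccc(S(=O)(=O)c2nc3ccccc3nc2Nc2cccc(N)c2)cc1` — 340 nM
compound 3 `Nc1ccc(Nc2nc3ccccc3nc2S(=O)(=O)c2ccc(Br)cc2)cc1` — 1020 nM

Compound 2 differs from compound 1 as follows: 3-aminophenyl in place of 4-aminophenyl on a nitrogen on an aromatic ring
That change gives an 8.8-fold lower number from compound 1 to compound 2 (0.94 log units; beyond the scatter).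

Compound 3 differs from compound 1 in the core: bromo in place of methoxy on an aromatic carbon
That change gives a 2.9-fold lower number from compound 1 to compound 3 (0.47 log units; beyond the scatter). Compound 3 stands between compound 1 and compound 2 in this assay, with both gaps beyond the scatter.

Compound 4 `Nc1cccc(Nc2nc3ccccc3nc2S(=O)(=O)c2ccc(Br)cc2)c1` is not yet measured. It differs from compound 3 as follows: 3-aminophenyl in place of 4-aminophenyl on a nitrogen on an aromatic ring
The surroundings of the place are the same word for word as in the change from compound 1 to compound 2, so this is the same change, made on a core that differs by bromo in place of methoxy. The change has been seen once, on the core of compound 1, where it gave an 8.8-fold lower number from compound 1 to compound 2 (0.94 log units; beyond the scatter). From the compounds shown here alone, whether it carries over to the core of compound 3 is unknown; one prior case is a thin base. The expectation for compound 4 is a step of about a 7.3-fold lower number from compound 3 to compound 4 (0.86 log units; beyond the scatter), slightly less than the earlier one to allow for the change of core, resting on compound 3 at 1020 nM and the step of an 8.8-fold lower number from compound 1 to compound 2 (0.94 log units; beyond the scatter). Compound 4 is therefore estimated at 140 nM in this assay, likely between 50 nM and 400 nM.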

Compound 4, half-maximal inhibitory concentration: 1120 nM
Estimate against measurement, compound 4: 8.0-fold (0.90 log units) below, and the stated range ends below it.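

In this assay the swap of 4-aminophenyl for 3-aminophenyl does not carry over from the methoxy core to the bromo core, where the step is a 1.1-fold higher number from compound 3 to compound 4 (0.04 log units; within the scatter) and the pair cannot be told apart, so the same swap gives clearly different results on the two cores: the same change on two cores in this assay, an 8.8-fold lower number (0.94 log units; beyond the scatter) from compound 1 to compound 2 and a 1.1-fold higher number (0.04 log units; within the scatter) from compound 3 to compound 4, 9.7-fold (0.98 log units) apart, beyond the scatter of two such steps

Read the other way, the effect of bromo in place of methoxy depends on which aminophenyl group is present, with the step on the 3-aminophenyl pair being a 3.3-fold higher number from compound 2 to compound 4 (0.52 log units; beyond the scatter), opposite in direction to the step on the 4-aminophenyl pair: the same change on two cores in this assay, a 2.9-fold lower number (0.47 log units; beyond the scatter) from compound 1 to compound 3 and a 3.3-fold higher number (0.52 log units; beyond the scatter) from compound 2 to compound 4, 9.7-fold (0.98 log units) apart, beyond the scatter of two such steps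

The two changes are thus not additive in these compounds, but this rests on a single set of four and does not show why the steps differ or which behaviour would hold on a further core.

From the compounds shown here alone, whether the gain from 3-aminophenyl is confined to methoxy or also appears with a chloro or methyl group in that place remains open. Also open, going by these compounds, is how an amide or hydroxy group in place of the amino group would behave on either core.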